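Pyridazinone amides: a bromofluorophenyl variant on the ring nitrogen

The source may hold more compounds than are shown below. What is called first, only, known or untested is meant among the compounds shown, and "the series" means these compounds.

Measured compounds:
compound 1, `CNC(=O)c1cc(Oc2ccc(NC(=O)c3nn(-c4cccc(F)c4)c(=O)cc3C)cc2F)ccn1`: 6410 nM
compound 2, `Cc1cc(=O)n(-c2ccccc2C(F)(F)F)nc1C(=O)Nc1ccc(Oc2ncnc3ccsc23)cc1`: 5550 nM

Of the compounds shown here, two have so far been tested in a functional assay on MCF7 cells (Homo sapiens) for cytotoxicity, read by MTT assay, with a stated time of 72 h; a lower number here means a stronger inhibitor, a higher number a weaker inhibitor. Compound 1 gives 6410 nM in this assay, and compound 2 gives 5550 nM. Compound 2 holds the lower of the two numbers, but compound 1 sits within the scatter of it, so the two values cannot be ordered with any confidence. Among the measured compounds shown here, the two compounds also differ in more than one place, so no single step between them is counted.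

Compound 3, `Cc1cc(=O)n(-c2ccc(Br)cc2F)nc1C(=O)Nc1ccc(Oc2ncnc3ccsc23)cc1`, has not yet been measured in this assay. It differs from compound 2 in one place: 4-bromo-2-fluorophenyl in place of 2-(trifluoromethyl)phenyl on an aromatic nitrogen. For the measured compounds named here, there is no measured pair that isolates this kind of exchange, so the expectation rests on the values of compound 2 and compound 1 alone, which are close to each other. The author expects a step from compound 2 to compound 3 of a 1.4-fold lower number from compound 2 to compound 3 (0.14 log units; within the scatter), not clearly beyond the scatter. Compound 3 is therefore estimated at 4000 nM in this assay, with a range from 1200 nM to 13000 nM.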

Compound 3, half-maximal inhibitory concentration: 9360 nM
Beside the measured number, compound 3's estimate is 2.3-fold (0.37 log units) below it; the measured number falls inside the stated range.
By their numbers in this assay, from the lowest: compounds 2, 1 and 3 (each within the scatter of the next).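

Among the compounds shown here, this step is the first measured exchange at this place, the aromatic nitrogen of the six-membered aromatic ring with 2 nitrogen, since compound 1 and compound 2 differ in more than one place. Putting 4-bromo-2-fluorophenyl in place of 2-(trifluoromethyl)phenyl gives a 1.7-fold higher number from compound 2 to compound 3 (0.23 log units; within the scatter) in this assay, so this exchange, in which a bromine and a fluorine enter, the trifluoromethyl leaves and the group goes from 10 heavy atoms to 8, does not move the number clearly beyond the scatter. Nothing available bears on why the step has this size.

On these data alone, both groups at this place are halogen-bearing phenyl rings, so it remains open whether an unsubstituted phenyl, a methoxyphenyl, an aminophenyl, a cyclohexyl or a plain methyl on the same nitrogen would give a number clearly apart from these. As far as these compounds go, it is also open whether the same exchange would give a similar step on the core of compound 1, which carries 3-fluorophenyl at this place.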